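This account rests on a few compounds, and the source may have more. Where it says the series, first, only, none or still open, it means among the compounds named here.

In a functional assay on KB cells (Homo sapiens) for inhibition, read by MTT assay, with a stated time of 24 h, tested at 10 ug/mL (on this read-out lower numbers stand for less inhibition of growth and higher numbers for more inhibition of growth at the one concentration tested), compound 1 `O=C(CCCCC1CCSS1)Nc1cccc(C(F)(F)F)c1` gives 10.9%, compound 2 `O=C(CCCCC(S)CCS)Nc1ccc(OC(F)(F)F)cc1` gives 15%, and compound 3 `CC(=O)SCCC(CCCCC(=O)Nc1ccccc1)SC(C)=O` gives 2.5%. Compound 3 therefore stands within the usual scatter of compound 1, while compound 2 lies above it by more than that scatter.

The next compound, compound 4 `CC(=O)SCCC(CCCCC(=O)Nc1ccc(Cl)cc1)SC(C)=O`, differs from compound 3 in one place, where a chloro takes the place of a hydrogen on an aromatic carbon: chloro in place of hydrogen on an aromatic carbon. Going by the values given here, no two measured compounds differ in only one place, so the data give no direct measure of this kind of change. Compound 1 also bears a group on its aromatic ring and, at 10.9%, stays within the scatter of compound 3, although the two differ elsewhere as well, so this is weak guidance. A small upward change in this assay is expected, with a number 3.5 percentage points higher from compound 3 to compound 4 (within the scatter) estimated to stay within the scatter. For compound 4 the estimated value is 6%, with an expected range from 0% to 18%.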

Compound 4, percent growth inhibition at one concentration: 18.1%
Estimate against measurement, compound 4: 12.1 percentage points below, outside the stated range (above it).
By their numbers in this assay, from the lowest: compounds 3, 1, 2 and 4 (each within the scatter of the next, the first and the last beyond it).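

In this assay, placing a chloro in the position of a hydrogen, on an aromatic carbon para to a large group, gives a number 15.6 percentage points higher from compound 3 to compound 4 (beyond the scatter). Going by these compounds alone, this is the first single change in the set that can be read directly, and it shows that this one ring position can, with the rest of the molecule held the same, move the number by more than the usual scatter. No measurement at hand explains why the chloro has this effect.

On these data alone, whether this rise is specific to chlorine or would also come with another group at the same carbon, such as a fluoro, a methoxy or an amine, stays open. As far as these compounds go, it is also open whether the same swap would raise the number on the cores of compound 1 and compound 2, which carry their sulfur atoms differently.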